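This account rests on a few compounds, and the source may have more. Where it says the series, first, only, none or still open, it means among the compounds named here.

Series notes, a functional assay on MIA PaCa-2 cells (Homo sapiens) for inhibition, read by MTT assay, with a stated time of 72 h; on this read-out lower numbers stand for stronger inhibition and higher numbers for weaker inhibition

- Compound 1 `COc1cc(NC(C)CCCNC(=O)Nc2cccc(Cl)c2)c2ncccc2c1`: 21000 nM
- Compound 2 `COc1cc(NC(C)CCCNC(=O)Nc2ccc(F)cc2)c2ncccc2c1`: 21000 nM

Among the measured compounds shown here, compound 2 stands level with compound 1 at the digits given, and the only measured step, no change at the digits printed from compound 1 to compound 2 (within the scatter), lies within the scatter. Compound 3 `COc1cc(NC(C)CCCNC(=O)NNC(=O)Nc2ccc(O)cc2)c2ncccc2c1` has not yet been measured in this assay. Its difference from compound 2 is ((4-hydroxyphenyl)carbamoyl)amino in place of 4-fluorophenyl on an amide-type nitrogen. For the measured compounds named here, the one measured step exchanged one aryl group for another on that same amide-type nitrogen and produced no change in this assay; the change to compound 3 is of a different kind, with the entering group placing a further carbamoylamino unit and a hydroxyphenyl where compound 2 carries the fluorophenyl directly. Going by the values given here, no measured pair covers such a change, so the expectation for compound 3 rests only on the flat step from compound 1 to compound 2. The expected step from compound 2 to compound 3 in this assay is a 1.2-fold higher number from compound 2 to compound 3 (0.08 log units; within the scatter), small and not clearly beyond the scatter, with a wide range to cover the untested kind of change. For compound 3 the estimate in this assay is therefore 25000 nM, with a range from 7000 nM to 90000 nM.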

Compound 3, half-maximal inhibitory concentration: 142000 nM
Estimate against measurement, compound 3: 5.7-fold (0.75 log units) below, outside the stated range (above it).
By their numbers in this assay, from the lowest: compounds 1 and 2 (each within the scatter of the next); then compound 3.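

In this assay the exchange of one halogenated phenyl group for another on the amide-type nitrogen left the number unmoved, but ((4-hydroxyphenyl)carbamoyl)amino in place of 4-fluorophenyl gives a 6.8-fold higher number from compound 2 to compound 3 (0.83 log units; beyond the scatter) and the same group in place of 3-chlorophenyl gives a 6.8-fold higher number from compound 1 to compound 3 (0.83 log units; beyond the scatter) on that nitrogen. This position is therefore not indifferent to what it carries: the level pair of compound 1 and compound 2 spoke only to a swap between directly attached aryl groups, whereas the larger entering group, which brings hydrogen-bond donors and acceptors absent from both of those aryl groups, moves the read-out beyond the scatter toward weaker inhibition. Nothing at hand gives a measured reason for this shift.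

The compounds shown do not separate the two parts of the change, the added carbamoylamino unit and the hydroxyl on the phenyl ring; 4-hydroxyphenyl directly on the nitrogen, or 4-fluorophenyl carried on the carbamoylamino unit, would each alter only one. Also open, on these data alone, is how this nitrogen responds to other kinds of group, such as a plain alkyl chain or a phenyl bearing a carboxylic acid or an amine.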